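The compounds below may be only part of what the source reports. "The series", "measured", "known", "first", "only" and "open" are said of these compounds alone.

The measured compounds: compound 1, `COc1ccc(Cn2c(-c3ccccc3)c(-c3ccccc3)c3c(=N)n([C@H]4CC[C@H](O)CC4)cnc32)cc1`, which in an ADME assay on microsomes from liver (Mus musculus, strain CD1) for metabolic stability, read by LC-MS, using NADPH, with a stated time of 60 min (on this read-out higher numbers stand for a longer-lived compound and lower numbers for a shorter-lived compound), gives 2 h; and compound 2, `N=c1c2c(-c3ccccc3)c(-c3ccccc3)n(Cc3ccccc3)c2ncn1CCCN1CCN(c2ccccc2)CC1`, which in this assay gives 0.233 h.

Compound 1 stands highest of the two numbers. Compound 2 gives the lower one, and the gap between them lies beyond the scatter. The two compounds differ at more than one place, so that gap says nothing about any single change.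

Compound 3, `COc1ccc(Cn2c(-c3ccccc3)c(-c3ccccc3)c3c(=N)n(CCO)cnc32)cc1`, has not yet been measured in this assay. It differs from compound 1 in one place: 2-hydroxyethyl in place of 4-hydroxycyclohexyl on an aromatic nitrogen. For the measured compounds named here, no measured pair shows this change, so there is no step to lean on. In the absence of one, compound 3 is expected to give a number close to that of compound 1, with a step of a 1.7-fold lower number from compound 1 to compound 3 (0.22 log units; within the scatter) that is expected to lie within the scatter or only a little beyond it towards a shorter-lived compound. Compound 3 is estimated at 1.2 h, with a range from 0.4 h to 3.5 h.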

Compound 3, half-life: 0.518 h
The estimate for compound 3 lay 2.3-fold (0.36 log units) above the measured number, within the range that was stated.
By their numbers in this assay, from the lowest: compound 2; then compound 3; then compound 1.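

For the compounds shown here, the change of 4-hydroxycyclohexyl to 2-hydroxyethyl on this aromatic nitrogen is the first single change that can be read here, and in this assay it gives a 3.9-fold lower number from compound 1 to compound 3 (0.59 log units; beyond the scatter) and so shows that this position bears on the half-life. Both groups carry one hydrogen-bond donor and one hydrogen-bond acceptor, so the step comes with equal counts of these, while the six-membered ring of carbon and the two defined stereocentres leave and the heavy atoms fall from 7 to 3. Nothing shown here accounts for the step.

On these data alone, whether the ring itself or simply the size of the group goes with the longer half-life remains open. As far as these compounds go, it is also open how a longer chain such as 3-hydroxypropyl, or an amine in place of the hydroxyl on the cyclohexyl ring, would behave at this position.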